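Adding a Methyl to Compound 2: Expected Cell Toxicity

The source may report more compounds than this note shows. Statements on the series, on what has been measured and on what is new or still open speak of the compounds shown alone.

Measured so far:
compound 1, `CC(CO)NC(=O)/C=C/c1ccccc1`, 98% in a toxicity assay on HepG2 cells (Homo sapiens) for cytotoxicity, read by trypan blue exclusion, with a stated time of 24 h, tested at 25 uM; a higher number here means a weaker effect of the compound at the concentration tested, a lower number a stronger effect
compound 2, `CC(O)CNC(=O)/C=C/c1ccccc1`, 99%

Compound 2 stands highest of the two numbers, yet its step of a number 1 percentage points higher from compound 1 to compound 2 (within the scatter) is within the scatter, so the two compounds cannot be told apart. Compound 3, `CCC(O)CNC(=O)/C=C/c1ccccc1`, carries the change (methyl in place of hydrogen on a saturated chain carbon, two bonds along the chain from an oxygen on a saturated carbon). Among the measured compounds shown here, only the step from compound 1 to compound 2 has been seen, and it was flat. The step of a number 1 percentage points lower from compound 2 to compound 3 (within the scatter) is therefore expected to stay within the scatter as well. Compound 3 is estimated at 98%, with a range from 90% to 103%.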

Compound 3, a percentage reported as activity, at one concentration (the size of the read-out at that concentration, not a potency): 97%
For compound 3 the middle estimate is 1 percentage points above the measured one; low and high end bracket the measured number.
By their numbers in this assay, from the lowest: compounds 3, 1 and 2 (each within the scatter of the next).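

On the saturated chain carbon, two bonds along the chain from an oxygen on a saturated carbon, methyl in place of hydrogen turns 2-hydroxypropyl into 2-hydroxybutyl and gives, in this assay, a number 2 percentage points lower from compound 2 to compound 3 (within the scatter). The 2-hydroxybutyl group in place of 1-(hydroxymethyl)ethyl gives a number 1 percentage points lower from compound 1 to compound 3 (within the scatter), so the three side chains cannot be told apart at the tested concentration. Nothing available explains this result. Going by these compounds, how a longer chain, an amine or a carboxylic acid on this carbon would read remains open.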